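Swapping the Group on the Ring Nitrogen of Compound 1

This account rests on a few compounds, and the source may have more. Where it says the series, first, only, none or still open, it means among the compounds named here.

Compound 1 `CCOC(=O)C1=Cc2ccccc2OC1(OCc1cn(CC(=O)Nc2cccc(Cl)c2)nn1)C(F)(F)F` was tested in a functional assay on MCF7 cells (Homo sapiens) for inhibition, read by MTT assay, with a stated time of 24 h (a higher number here means a weaker inhibitor, a lower number a stronger inhibitor), where compound 1 gives 11600 nM. This is the lowest of the two numbers in hand; compound 3 `O=C(O)C1=Cc2ccccc2OC1(OCc1cc(-c2ccc(F)cc2)no1)C(F)(F)F` gives 64200 nM. For compound 2 `O=C(O)C1=Cc2ccccc2OC1(OCc1cc(-c2ccc(F)cc2F)no1)C(F)(F)F` only a limit is reported, > 150000 nM. Among the measured compounds shown here, the single measured step, an at least 2.3-fold lower number from compound 2 to compound 3 (0.36 log units; beyond the scatter), concerns hydrogen in place of fluoro on an aromatic carbon. Compound 4 `CCOC(=O)C1=Cc2ccccc2OC1(OCc1cn(-c2ccc(C)cc2)nn1)C(F)(F)F` is not yet measured; it differs from compound 1 by 4-methylphenyl in place of ((3-chlorophenyl)carbamoyl)methyl on an aromatic nitrogen. For the measured compounds named here, no measured step touches a change of this kind, so its size cannot be read from the data, and no shift beyond the scatter is assumed. Compound 4 is therefore expected to give about 15000 nM in this assay, between 5000 nM and 60000 nM. The expected step is a 1.3-fold higher number from compound 1 to compound 4 (0.11 log units; within the scatter).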

Compound 4, half-maximal inhibitory concentration: 26700 nM
The estimate for compound 4 lay 1.8-fold (0.25 log units) below the measured number, within the range that was stated.
By their numbers in this assay, from the lowest: compound 1; then compound 4; then compound 3. At a limit, above all of these: compound 2.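

Setting 4-methylphenyl on the aromatic nitrogen in place of ((3-chlorophenyl)carbamoyl)methyl gives a 2.3-fold higher number from compound 1 to compound 4 (0.36 log units; beyond the scatter) in this assay, the first evidence that this nitrogen's substituent affects the reading. The step is modest, and the entering group has neither the hydrogen-bond donor nor the hydrogen-bond acceptor counted in the leaving group. Nothing measured here explains the step. Whether the carbamoyl link or the chlorine of the leaving group accounts for it remains open. So does how a longer chain ending in an amine would read on this nitrogen.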